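A few compounds are considered here, and "the series" means these few. Any claim that something is new, unique, unknown or untested is made for them only; others in the source may bear on it.

For the measured compounds named here, in a functional assay on MCF7 cells (Homo sapiens) for inhibition, read by MTT assay (a lower number here means a stronger inhibitor, a higher number a weaker inhibitor), only two compounds have numbers so far. Compound 1 (`Cc1ccc(-c2nnc(NC(=O)CCCCCCC(=O)NO)s2)o1`) gives 880 nM, and compound 2 (`O=C(CCCN1CCN(C(=O)Nc2cccc3ncccc23)CC1)NO`) gives 7190 nM. Compound 1 therefore holds the lower of the two numbers, which makes it the stronger inhibitor of this pair, and the gap between them lies beyond the usual scatter of repeated measurements. The two structures differ in more than one place, so that gap cannot be pinned on any single group.

The next compound, compound 3 (`O=C(CCCCCCC(=O)Nc1nnc(-c2ccc(Br)o2)s1)NO`), keeps the core of compound 1 and changes one small group: 5-methylfuran-2-yl becomes 5-bromofuran-2-yl, with bromo in place of methyl on an aromatic carbon. Going by the values given here, no measured pair yet shows what a swap of this kind does in this assay, so the forecast has little to lean on. The change is confined to one substituent, and the expected outcome is no step beyond the scatter, with no firm direction. The estimated change is a 1.2-fold lower number from compound 1 to compound 3 (0.07 log units; within the scatter). Compound 3 is expected to give about 750 nM, with an estimated range from 250 nM to 2200 nM.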

Compound 3, half-maximal inhibitory concentration: 880 nM
Compound 3: middle estimate off by 1.2-fold (0.07 log units), on the low side, and the stated range covers the measured number.
By their numbers in this assay, from the lowest: compounds 1 and 3 (each within the scatter of the next); then compound 2.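

For the compounds shown here, exchanging 5-methylfuran-2-yl for 5-bromofuran-2-yl gives the first step in this assay that can be read at a single place, and bromo in place of methyl leaves the number unmoved (no change at the digits printed from compound 1 to compound 3 (within the scatter)). This position, on an aromatic carbon two ring bonds from the ring atom that bears a large group, can therefore carry either of these two single-atom-sized substituents, methyl or bromo, with compound 1 and compound 3 reading alike in this cell assay. There is no supporting measurement that explains why the two groups give the same reading.

One swap says little about the position as a whole: an amine, a carboxylic acid or a longer chain at this spot could still shift the number in either direction, and a bare hydrogen there would show whether the position needs a substituent at all. Compound 2 differs from the other two compounds in more than one place, so it cannot show which of its differences accounts for its higher number.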